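Series notes: anilide variation on a shared thiazolidinedione core

The source may hold more compounds than are shown below. What is called first, only, known or untested is meant among the compounds shown, and "the series" means these compounds.

Measured so far in an assay on isolated protein for inhibition of histone deacetylase 4 (Homo sapiens), with a stated time of 1 h; on this read-out lower numbers stand for stronger inhibition and higher numbers for weaker inhibition:
compound 1, `O=C(COc1ccc2cc(/C=C3/SC(=O)NC3=O)ccc2c1)Nc1ccccn1`, 17000 nM;
compound 2, `O=C(COc1ccc2cc(/C=C3/SC(=O)NC3=O)ccc2c1)Nc1ccc(F)cc1`, 1600 nM;
compound 3, `O=C(COc1ccc2cc(/C=C3/SC(=O)NC3=O)ccc2c1)Nc1ccc(Cl)c(Cl)c1`, 5500 nM.

Compound 3 stands second highest of the three numbers in this assay. Its nearest neighbour is compound 1, with a 3.1-fold lower number from compound 1 to compound 3 (0.49 log units; beyond the scatter); its furthest is compound 2, with a 3.4-fold higher number from compound 2 to compound 3 (0.54 log units; beyond the scatter). The largest step in the set is an 11-fold lower number from compound 1 to compound 2 (1.03 log units; beyond the scatter).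

The next compound, compound 4, is `O=C(COc1ccc2cc(/C=C3/SC(=O)NC3=O)ccc2c1)Nc1ccc(Br)cc1`. It differs from compound 3 in one place: 4-bromophenyl in place of 3,4-dichlorophenyl on an amide-type nitrogen.

The step that bears most directly on this change is a 3.4-fold higher number from compound 2 to compound 3 (0.54 log units; beyond the scatter), since compound 2 also carries a single halogen on the phenyl ring attached to the amide-type nitrogen, and compound 3 carries two. Reversing that direction, a modest lowering of the number is expected when going from compound 3 to compound 4 in this assay, roughly a 2.5-fold lower number from compound 3 to compound 4 (0.40 log units; beyond the scatter). Going by the values given here, no measured compound carries a bromine, so the size of the step is uncertain. Compound 4 is therefore estimated at 2200 nM in this assay, with a plausible range from 800 nM to 6000 nM.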

Compound 4, half-maximal inhibitory concentration: 2900 nM
Compound 4: the middle estimate sits 1.3-fold (0.12 log units) below what was measured; the measured number falls inside the stated range.
By their numbers in this assay, from the lowest: compounds 2, 4 and 3 (each within the scatter of the next, the first and the last beyond it); then compound 1.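

In this assay, 4-bromophenyl in place of 3,4-dichlorophenyl gives a 1.9-fold lower number from compound 3 to compound 4 (0.28 log units; within the scatter), and bromo in place of fluoro gives a 1.8-fold higher number from compound 2 to compound 4 (0.26 log units; within the scatter); the bromo anilide therefore cannot be separated from either of two neighbours that are separated from each other, so the measured gap between the single-halogen and dichloro anilides does not extend into a clean division by halogen count. The change from pyridin-2-yl remains the one clearly resolved change at this amide-type nitrogen, with a 5.9-fold lower number from compound 1 to compound 4 (0.77 log units; beyond the scatter) adding a third halogenated phenyl group that gives a lower number than the pyridin-2-yl group, and no compound shown goes against this. No evidence on hand accounts for these differences.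

Open, as far as these compounds go, is whether a 4-chlorophenyl group would also fall within the scatter of the fluoro and bromo anilides, which would help show how much the identity of a single halogen matters here. Also open, from the compounds shown here alone, is whether the lower numbers depend on a halogen at all, or whether a phenyl ring bearing a methoxy group, an amine or a carboxylic acid would hold them.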